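Notes on the step from compound 2 to compound 3

This account rests on a few compounds, and the source may have more. Where it says the series, first, only, none or still open, it means among the compounds named here.

Measured so far:
compound 1, `COc1cc(Cl)cc(-c2nn(-c3cccc(NC(=O)Nc4ccc(Cl)c(Cl)c4)c3)cc2-c2ccncc2)c1`: 69%
compound 2, `COc1cc(Cl)cc(-c2nn(-c3cccc(NC(=O)Nc4cccc(C(F)(F)F)c4)c3)cc2-c2ccncc2)c1`: 51%

In a functional assay on MDA-MB-468 cells (Homo sapiens) for inhibition, read by sulforhodamine B assay, with a stated time of 48 h, tested at 1 uM (a higher number here means a weaker effect of the compound at the concentration tested, a lower number a stronger effect), compound 1 gives 69%, and in this assay compound 2 gives 51%. Among the compounds with values here, the one step within this pair, a number 18 percentage points lower from compound 1 to compound 2 (beyond the scatter), touches only the aryl group on the amide-type nitrogen. Compound 2 stands lowest of the two numbers; its nearest neighbour is compound 1, higher by a margin beyond the scatter.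

Compound 3, `COc1cc(Cl)cc(-c2nn(-c3cccc(NC(=O)c4cccc(C(F)(F)F)c4)c3)cc2-c2ccncc2)c1`, is not yet measured. Its change from compound 2 is 3-(trifluoromethyl)phenyl in place of (3-(trifluoromethyl)phenyl)amino on a carbonyl carbon. Within the data shown here, no measured step bears on this change: the only step available, a number 18 percentage points lower from compound 1 to compound 2 (beyond the scatter), exchanges one aryl group for another and leaves the carbonyl linkage as it was. With nothing directly comparable, no step beyond the scatter is expected in this assay, the expected step being a number 7 percentage points higher from compound 2 to compound 3 (within the scatter). Compound 3 is therefore estimated at 58%, with a range from 35% to 85%.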

Compound 3, a percentage reported as activity, at one concentration (the size of the read-out at that concentration, not a potency): 50%
For compound 3 the middle estimate is 8 percentage points above the measured one; the range from low to high includes it.
By their numbers in this assay, from the lowest: compounds 3 and 2 (each within the scatter of the next); then compound 1.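

In this assay, the step with 3-(trifluoromethyl)phenyl in place of (3-(trifluoromethyl)phenyl)amino on the carbonyl carbon is a number 1 percentage points lower from compound 2 to compound 3 (within the scatter), so the read-out at this concentration does not separate the two linkages, and the amino nitrogen is not needed to keep it. The step of a number 19 percentage points lower from compound 1 to compound 3 (beyond the scatter) changes both the aryl group and the linkage; read with the step just given, it follows the aryl change rather than the loss of the amino nitrogen, at least for these compounds. Nothing available explains why the two linkages give such similar read-outs.

Going by these compounds, whether the 3,4-dichlorophenyl group behaves the same when attached directly to the carbonyl carbon remains open. Also open, on these data alone, is how a sulfonyl in place of the carbonyl, or a methylene inserted before the aryl group, would read in this assay.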